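This account rests on a few compounds, and the source may have more. Where it says the series, first, only, none or still open, it means among the compounds named here.

Working notes on the series.

Compound 1 `COc1ccc(CN2CCC(CCNC(=O)/C=C/c3cc(C(C)(C)C)c(O)c(C(C)(C)C)c3)CC2)cc1` is the reference point. In an assay on isolated protein for inhibition of Amine oxidase [flavin-containing] B (Homo sapiens), read by fluorescence, with stated times of 15 min and 20 min (a lower number here means a stronger inhibitor, a higher number a weaker inhibitor), compound 1 gives 6700 nM, the lowest of the two numbers recorded so far; the nearest is compound 2, and the gap between them is within the scatter. Compound 2 `CC(C)(C)c1cc(/C=C/C(=O)NCCC2CCN(Cc3ccc(F)c(F)c3)CC2)cc(C(C)(C)C)c1O` gives 9300 nM in this assay. Going by the values given here, the one measured step, a 1.4-fold higher number from compound 1 to compound 2 (0.14 log units; within the scatter), replaces the aryl group on the saturated chain carbon bound to the ring amine nitrogen and stays within the scatter.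

Compound 3 `CC(C)(C)c1cc(/C=C/C(=O)NCCC2CCN(Cc3ccc(C#N)cc3)CC2)cc(C(C)(C)C)c1O` has not been measured. It differs from compound 1 by cyano in place of methoxy on an aromatic carbon.

Among the compounds with values here, the only step that bears on this change is the aryl replacement from compound 1 to compound 2, which was within the scatter; no measured pair tests cyano against methoxy directly. With a substituent swap at the same aryl position having left the number essentially unchanged, the expectation for compound 3 is a step of about a 1.1-fold higher number from compound 1 to compound 3 (0.05 log units; within the scatter), that is, nothing beyond the scatter in either direction. The estimate for compound 3 in this assay is therefore 7500 nM, with a range of 3000 nM to 18000 nM.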

Compound 3, half-maximal inhibitory concentration: 13900 nM
Compound 3: the middle estimate sits 1.9-fold (0.27 log units) below what was measured, and the stated range covers the measured number.
By their numbers in this assay, from the lowest: compounds 1, 2 and 3 (each within the scatter of the next, the first and the last beyond it).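

In this assay, going by these compounds alone, cyano in place of methoxy on an aromatic carbon, para to a large group, gives the first step that lies beyond the scatter (a 2.1-fold higher number from compound 1 to compound 3 (0.32 log units; beyond the scatter)), so the substituent at this position can register in the read-out, although the step is modest. Within the data shown here, the step from the 3,4-difluorophenyl group to the 4-cyanophenyl group stays within the scatter (a 1.5-fold higher number from compound 2 to compound 3 (0.17 log units; within the scatter)), so compound 2 and compound 3 cannot be told apart, and the only separated pair is compound 1 and compound 3. Nothing at hand accounts for the separation of the 4-methoxybenzyl compound from the 4-cyanobenzyl compound.

From the compounds shown here alone, it remains open how an amine, a carboxylic acid or a simple hydroxyl on this aromatic carbon would read in this assay, and whether the separation of compound 1 from compound 3 would hold across further substituents. Also open is what a longer chain on the amide nitrogen of the shared core would do, as the compounds shown vary only the aryl group.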